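A few compounds are considered here, and "the series" means these few. Any claim that something is new, unique, unknown or untested is made for them only; others in the source may bear on it.

Measured in an in vivo ADME assay on the whole organism (strain 129/SvEvBrd x C57BL/6) for pharmacokinetics, with Mus musculus as the target; on this read-out higher numbers stand for higher oral bioavailability and lower numbers for lower oral bioavailability:
- compound 1 `CC(=O)c1nc([C@@H](O)[C@H](O)[C@H](O)CO)c(C)[nH]1`: 11%
- compound 2 `CC(O)c1nc([C@@H](O)[C@H](O)[C@H](O)CO)c[nH]1`: 22%
- compound 3 `CN(C)C(=O)c1nc([C@@H](O)[C@H](O)[C@H](O)CO)c[nH]1`: 5%

Compound 3, at 5%, cannot be told apart from compound 1, at 11%, since the two lie within the usual scatter of each other. Compound 2 stands clearly higher, at 22%.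

The unmeasured compound 4 `Cc1nc(-c2nc([C@@H](O)[C@H](O)[C@H](O)CO)c[nH]2)cs1` keeps the shared core of compound 3 and changes one group: 2-methyl-1,3-thiazol-4-yl in place of dimethylcarbamoyl on an aromatic carbon. In short, 2-methyl-1,3-thiazol-4-yl takes the place of dimethylcarbamoyl on an aromatic carbon.

Within the data shown here, one measured step bears on this change: a number 17 percentage points lower from compound 2 to compound 3 (beyond the scatter). It is a modest step, beyond the scatter, and it involves the same dimethylcarbamoyl group that leaves here. It shows that swapping this group can shift the number. However, no measured compound carries a ring at this place, so the data give only a rough guide to the effect of the new group.

Compound 3 at 5% leaves little room for a fall, so a modest rise is expected, of about the same size as that single step. The estimated change is a number 13 percentage points higher from compound 3 to compound 4 (beyond the scatter). For compound 4, the expected value is 18%, with an estimated range of 5% to 40%.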

Compound 4, oral bioavailability: 23%
Compound 4: the middle estimate sits 5 percentage points below what was measured; the range from low to high includes it.
By their numbers in this assay, from the lowest: compounds 3 and 1 (each within the scatter of the next); then compounds 2 and 4 (each within the scatter of the next).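

Placing 2-methyl-1,3-thiazol-4-yl on this aromatic carbon, between two ring nitrogen atoms, in place of dimethylcarbamoyl gives a number 18 percentage points higher from compound 3 to compound 4 (beyond the scatter) in this assay, which is the first sign that this position can carry an aromatic ring without a low result. Compared with 1-hydroxyethyl, the same ring gives a number 1 percentage points higher from compound 2 to compound 4 (within the scatter), so these two quite different groups cannot be told apart on this read-out, and the earlier a number 17 percentage points lower from compound 2 to compound 3 (beyond the scatter) does not apply to every group that replaces 1-hydroxyethyl. Nothing available here gives a reason for either step.

A single ring says little about rings at this position in general: the compounds shown do not tell whether the methyl group on the thiazole matters, or whether an unsubstituted thiazole, a phenyl ring or a pyridine would give a similar number. They also leave open how a carboxylic acid, an aminomethyl group or a longer chain would fare at this same place, and whether any group here can rise clearly beyond the numbers of compound 2 and compound 4.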